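Replacing the Carbonyl Substituent of Compound 1

The source may report more compounds than this note shows. Statements on the series, on what has been measured and on what is new or still open speak of the compounds shown alone.

Compound 1 `O=C(N1CCC(F)CC1)N1CC(c2nc(-c3cccc(Cl)c3)no2)C1` carries a 4-fluoropiperidin-1-yl group on a carbonyl carbon whose other neighbour is an amide-type nitrogen in a ring. In an assay on HEK293 cells for positive allosteric modulation of metabotropic glutamate receptor 5 (Homo sapiens), read by FLIPR (on this read-out higher numbers stand for an effect only at larger amounts of compound and lower numbers for an effect already at smaller amounts), compound 1 gives 990 nM. Two other compounds share the core of compound 1. Compound 2 `O=S(=O)(c1ccc(F)cc1)N1CC(c2nc(-c3cccc(Cl)c3)no2)C1` replaces the carbonyl with a sulfonyl group, and in this assay compound 2 reaches only a limit, > 10000 nM. In this assay (the limit of > 10000 nM in this assay, at which 1 of the 3 values shown sits). Compound 3 `Cc1ccc(C(=O)N2CC(c3nc(-c4cccc(F)c4)no3)C2)cc1` puts a methyl-substituted benzoyl group on the ring nitrogen and exchanges the chlorine of the pendant aromatic ring for fluorine; in this assay compound 3 gives 6800 nM. Of the two numbers shown, compound 1 stands lowest, and its gap to compound 3, the nearest, lies beyond the usual scatter.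

Compound 4 `O=C(C1CCC(F)(F)CC1)N1CC(c2nc(-c3cccc(Cl)c3)no2)C1` differs from compound 1 in one place: 4,4-difluorocyclohexyl in place of 4-fluoropiperidin-1-yl on a carbonyl carbon. Going by the values given here, no measured pair shows this change, so the step can only be estimated. The step from compound 1 to compound 4 in this assay is expected to be a 1.6-fold higher number from compound 1 to compound 4 (0.21 log units; within the scatter), a modest move that may stay within the scatter or slightly raise the number. Compound 4 is therefore expected to give about 1600 nM in this assay. That estimate for compound 4 spans from 450 nM to 6000 nM.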

Compound 4, half-maximal effective concentration: 180 nM
Beside the measured number, compound 4's estimate is 8.9-fold (0.95 log units) above it; the whole stated range lies above it.
By their numbers in this assay, from the lowest: compound 4; then compound 1; then compound 3. At a limit, above all of these: compound 2.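

In this assay, 4,4-difluorocyclohexyl in place of 4-fluoropiperidin-1-yl gives a 5.5-fold lower number from compound 1 to compound 4 (0.74 log units; beyond the scatter), the only comparison shown in which a single place changes. Compound 2 and compound 3 each differ from compound 1 in more than one way, so they could not isolate this position, whereas this step shows that the number responds to the ring on the carbonyl carbon by more than the usual scatter. It also shows that a ring nitrogen in this group is not needed for an effect in this assay, since the carbon-only ring of compound 4 gives the lower number, and no measurement shown accounts for the size of this step.

The step swaps the ring nitrogen for carbon and also adds a second fluorine, so the compounds shown do not tell these two changes apart; 4,4-difluoropiperidin-1-yl and 4-fluorocyclohexyl would each carry only one of them. Also open, as far as these compounds go, is how an unfluorinated cyclohexyl, or a morpholine at the same place, would compare with compound 4.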